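A Linker Change Awaiting Its Measurement

A few compounds are considered here, and "the series" means these few. Any claim that something is new, unique, unknown or untested is made for them only; others in the source may bear on it.

Of the compounds shown here, two of this study have been measured. Compound 1 `COc1cc(Cl)cc(-c2nn(-c3cccc(NC(=O)Nc4ccc(Cl)c(C(F)(F)F)c4)c3)cc2-c2ccncc2)c1` gives 91% in a functional assay on K562 cells (Homo sapiens) for inhibition, read by sulforhodamine B assay, with a stated time of 48 h, tested at 0.1 uM; on this read-out lower numbers stand for a stronger effect and higher numbers for a weaker effect at the one concentration tested. For the measured compounds named here, compound 2 `COc1cc(Cl)cc(-c2nn(-c3cccc(NC(=O)Nc4cccc(C(F)(F)F)c4)c3)cc2-c2ccncc2)c1` gives 94% in this assay, and the only step available, a number 3 percentage points higher from compound 1 to compound 2 (within the scatter), shows that the two sit together within the scatter, so compound 2 stands alongside compound 1 without a distinguishable order between them.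

The next compound, compound 3 `COc1cc(Cl)cc(-c2nn(-c3cccc(NC(=O)c4cccc(C(F)(F)F)c4)c3)cc2-c2ccncc2)c1`, differs from compound 2 in one place: 3-(trifluoromethyl)phenyl in place of (3-(trifluoromethyl)phenyl)amino on a carbonyl carbon. Going by the values given here, no measured step concerns this part of the molecule; the step from compound 1 to compound 2 touches a different position and was itself within the scatter, so it gives no direct guide here. Among the compounds with values here, with both measured numbers close together and no bearing step, the expectation is that compound 3 will not move beyond the scatter, and the expected step is a number 2 percentage points lower from compound 2 to compound 3 (within the scatter) in this assay. Compound 3 is therefore estimated at 92% in this assay, with a range from 76% to 102%.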

Compound 3, a percentage reported as activity, at one concentration (the size of the read-out at that concentration, not a potency): 112%
For compound 3 the middle estimate is 20 percentage points below the measured one, and the stated range ends below it.
By their numbers in this assay, from the lowest: compounds 1 and 2 (each within the scatter of the next); then compound 3.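

Unlike the chloro change between the earlier compounds, the change on the carbonyl carbon produces a shift that can be read in this assay: replacing (3-(trifluoromethyl)phenyl)amino with 3-(trifluoromethyl)phenyl gives a number 18 percentage points higher from compound 2 to compound 3 (beyond the scatter), which means a weaker effect at the one concentration tested. The comparison with the chloro-bearing compound points the same way, with a number 21 percentage points higher from compound 1 to compound 3 (beyond the scatter), so the weaker effect appears from either amino-bearing compound, and the change removes the nitrogen and the one hydrogen-bond donor counted in the group that leaves. The data shown offer nothing that says what lies behind this shift.

The compounds shown leave open whether the loss follows from removing the amino nitrogen as such, since no compound here carries a methylene group or an ether oxygen in its place on the carbonyl carbon. They also leave open whether a chloro substituent on the 3-(trifluoromethyl)phenyl group would make any difference once that group sits directly on the carbonyl carbon, and how any of the three compounds would read at other concentrations.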